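The compounds below may be only part of what the source reports. "The series", "measured", "known", "first", "only" and "open" are said of these compounds alone.

The measured compounds:

Compound 1, `CCN(CC)c1nc(C)nc2c(-c3ccc(OC)c(C)c3C)c(C)nn12`, gives 38.6 nM in an assay on cell membranes for displacement of a labelled ligand from corticotropin-releasing factor receptor 1 (Rattus norvegicus); a higher number here means a weaker inhibitor, a lower number a stronger inhibitor.
Compound 2, `CCC(CC)Nc1nc(C)nc2c(-c3cc(F)c(OC)cc3Cl)c(C)nn12`, gives 1 nM in this assay.
Compound 3, `CCN(CCC#N)c1nc(C)nc2c(-c3c(C)cc(OC)cc3OC)c(C)nn12`, gives 2.48 nM in this assay.

Among these three numbers, compound 3 holds the second highest. Its nearest neighbour is compound 2, whose number is lower by a margin beyond the usual scatter of repeated measurements; the furthest is compound 1, whose number is higher by a margin far beyond that scatter. Among the measured compounds shown here, compounds 1 and 2 differ from compound 3 in more than one place, so none of the measured pairs shows a single, clean change.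

Compound 4, `CCCN(CCC)c1nc(C)nc2c(-c3c(C)cc(OC)cc3OC)c(C)nn12`, has not yet been measured. It differs from compound 3 in one place: dipropylamino in place of (2-cyanoethyl)(ethyl)amino on an aromatic carbon. The chain that carried the nitrile is exchanged for a second propyl chain, and the group is left with one hydrogen-bond acceptor instead of two, as the comparison of the two structures shows.

For the measured compounds named here, no measured pair shows this exchange, so the expectation for the step in this assay rests on compound 3 alone. A step within the scatter, or a small one in either direction, is expected. For compound 4 the estimated number is 2 nM, within a range from 0.5 nM to 8 nM, which is an expected step of a 1.2-fold lower number from compound 3 to compound 4 (0.09 log units; within the scatter).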

Compound 4, half-maximal inhibitory concentration: 3.72 nM
Compound 4: the middle estimate sits 1.9-fold (0.27 log units) below what was measured; the measured number falls inside the stated range.
By their numbers in this assay, from the lowest: compound 2; then compounds 3 and 4 (each within the scatter of the next); then compound 1.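

In this assay the exchange of (2-cyanoethyl)(ethyl)amino for dipropylamino gives a 1.5-fold higher number from compound 3 to compound 4 (0.18 log units; within the scatter) and so stays within the scatter of repeated measurements. Among the compounds shown here, on this aromatic carbon between two ring nitrogen atoms, the nitrile-bearing group and an all-carbon pair of chains of the same heavy-atom count, 7 including the attached nitrogen, therefore cannot be told apart by this measurement, something the earlier compounds could not show because they differ from one another in more than one place. No measurement is available here that would explain why the two groups read alike.

Still open, as far as these compounds go, is whether this position accepts groups of a different kind on the same core, such as bis(2-methoxyethyl)amino, which carries ether oxygens in both chains, or morpholine, which closes the amine into a ring. For the compounds shown here, it also remains open whether the same exchange would read alike with the differently substituted aromatic rings of compound 1 and compound 2, since only one ring pattern carries both groups here.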